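Ester-bearing chains on the amide nitrogen of the shared core

The compounds below may be only part of what the source reports. "The series", "measured", "known", "first", "only" and "open" are said of these compounds alone.

Compound 1 `CC(C)CNC(=O)c1[nH]cnc1C(=O)Nc1ccc(Cl)c(Cl)c1` is the reference point. In a functional assay on HL-60 cells (Homo sapiens), with a stated time of 4 days (on this read-out lower numbers stand for stronger inhibition and higher numbers for weaker inhibition), compound 1 gives 7200 nM, the lowest of the two numbers recorded. Compound 2 `Cc1ccc(CNC(=O)c2[nH]cnc2C(=O)Nc2ccc(Cl)c(Cl)c2)cc1` gives 15200 nM in this assay, and the step of a 2.1-fold higher number from compound 1 to compound 2 (0.32 log units; beyond the scatter) is modest. Compound 3 `COC(=O)[C@@H](C)NC(=O)c1[nH]cnc1C(=O)Nc1ccc(Cl)c(Cl)c1` reaches only the limit of this assay: compound 3 gives > 62500 nM. The steps of an at least 8.6-fold higher number from compound 1 to compound 3 (0.93 log units; beyond the scatter) and an at least 4.1-fold higher number from compound 2 to compound 3 (0.61 log units; beyond the scatter) both point towards weaker inhibition.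

Compound 4 `C[C@H](NC(=O)c1[nH]cnc1C(=O)Nc1ccc(Cl)c(Cl)c1)C(=O)OC(C)(C)C` has not been measured in this assay. The change from compound 1 is 1-(tert-butoxycarbonyl)ethyl in place of isobutyl on an amide-type nitrogen. For the measured compounds named here, the closest precedent is the step of an at least 8.6-fold higher number from compound 1 to compound 3 (0.93 log units; beyond the scatter), where the entering group is likewise a 1-(alkoxycarbonyl)ethyl chain on the same amide-type nitrogen; its size is known only as the limit of > 62500 nM in this assay, at which 1 of the 3 values shown sits. The other steps, from compound 1 and compound 2 to compound 3, add no contrary case. A step in the direction of weaker inhibition, at least modest and possibly reaching the limit again, is therefore expected. Compound 4 is estimated at 50000 nM, with a range from 15000 nM to 160000 nM. The expected step is a 6.9-fold higher number from compound 1 to compound 4 (0.84 log units; beyond the scatter).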

Compound 4, half-maximal inhibitory concentration: 2400 nM
Compound 4: middle estimate off by 21-fold (1.32 log units), on the high side; the measured number lies below the stated range.
By their numbers in this assay, from the lowest: compound 4; then compound 1; then compound 2. At a limit, above all of these: compound 3.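

On the amide-type nitrogen, a 1-(alkoxycarbonyl)ethyl chain is not in itself poor in this assay, since the chain in compound 4 gives an at least 26-fold lower number from compound 3 to compound 4 (1.41 log units; beyond the scatter). The same chain also outperforms both ester-free chains, with a 3.0-fold lower number from compound 1 to compound 4 (0.48 log units; beyond the scatter) and a 6.3-fold lower number from compound 2 to compound 4 (0.80 log units; beyond the scatter), so the lowest number in the series comes from an ester-bearing chain, and compound 3 is the case against any general ester trend. The step from compound 3 is open-ended, as compound 3 stands at a limit: the limit of > 62500 nM in this assay, at which 1 of the 4 values shown sits.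

As drawn, compound 3 and compound 4 have opposite configurations at the chain stereocentre, so the effects of the ester group and of configuration remain unseparated. On these data alone, the methyl ester with the configuration of compound 4, an ethyl ester and the free carboxylic acid remain open.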